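The compounds below may be only part of what the source reports. "The series", "measured", "known", "first", "only" and "open" are said of these compounds alone.

Compound 3 `COc1nc(-c2ccncc2)ccc1[C@@H](c1ccccc1)[C@@](O)(CCN(C)C)c1cccc2ccccc12` carries a pyridin-4-yl group on the shared core. In a toxicity assay on Vero cells (Chlorocebus sabaeus) for cytotoxicity (a higher number here means that more compound is tolerated, a lower number that less compound is tolerated), compound 3 gives > 50 ug/mL, which is a limit of the assay and not a number. Compound 1 `COc1nc(-c2ccccc2F)ccc1[C@@H](c1ccccc1)[C@@](O)(CCN(C)C)c1cccc2ccccc12` gives in this assay > 50 ug/mL, again a limit. Compound 2 `COc1nc(-c2ccc(Br)cc2)ccc1[C@@H](c1ccccc1)[C@@](O)(CCN(C)C)c1cccc2ccccc12` gives in this assay > 50 ug/mL, also a limit. Because all three values sit at the limit of > 50 ug/mL in this assay, at which 3 of the 3 values shown sit, the steps a step that the two limits leave unreadable from compound 1 to compound 2, a step that the two limits leave unreadable from compound 1 to compound 3 and a step that the two limits leave unreadable from compound 2 to compound 3 cannot be sized; they show only that each of the three aryl variations stays at the limit. Compound 4 `COc1nc(-c2ccc(OC(F)(F)F)cc2)ccc1[C@@H](c1ccccc1)[C@@](O)(CCN(C)C)c1cccc2ccccc12` differs from compound 3 in one place: 4-(trifluoromethoxy)phenyl in place of pyridin-4-yl on an aromatic carbon. No measured step can be read for this change, so there is nothing to size it by; what the three measured compounds do show is that each variation at this position has stayed at the limit. The expected step is a step that the limit leaves unreadable from compound 3 to compound 4, no change beyond the scatter. Compound 4 is therefore estimated to give 60 ug/mL in this assay, within a range from 30 ug/mL to 120 ug/mL, most likely reported again only as a limit.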

Compound 4, half-maximal cytotoxic concentration: > 50 ug/mL
Compound 4 was reported as a limit (the forecaster's own chance of this, stated with the estimate: 75%); the middle value is on the limit's open side.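

Compound 4 also sits at a limit in this assay, so its steps from compound 1, compound 2 and compound 3 cannot be read: the limit of > 50 ug/mL in this assay, at which 4 of the 4 values shown sit. The four compounds leave open what concentration of each is actually tolerated, and whether these aryl groups differ at all.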